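From 1H-indol-6-yl to quinolin-3-yl on an amine nitrogen

This account rests on a few compounds, and the source may have more. Where it says the series, first, only, none or still open, it means among the compounds named here.

- compound 1 `O=C(/C=C\Nc1ccc2cc[nH]c2c1)c1nc(-c2ccc(C(F)(F)F)cc2)n2ccccc12` gives > 30000 nM
- compound 2 `COc1ccc(N/C=C\C(=O)c2nc(-c3ccc(OC)cc3)n3ccccc23)cc1` gives 2120 nM

In a functional assay on B16-F10 cells (Mus musculus) for cytotoxicity, read by MTT assay, with a stated time of 48 h (a lower number here means a stronger inhibitor, a higher number a weaker inhibitor), compound 1 has only a limit and no number, and that is the limit of > 30000 nM in this assay, at which 1 of the 2 values shown sits, here. The other measured compound, compound 2, gives a true number of 2120 nM in the same test. For the measured compounds named here, no step between measured compounds that differ in one place is available, so the account has only these two values to work from.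

Compound 3 `O=C(/C=C\Nc1cnc2ccccc2c1)c1nc(-c2ccc(C(F)(F)F)cc2)n2ccccc12` keeps the core of compound 1 and carries quinolin-3-yl in place of 1H-indol-6-yl on an amine nitrogen for its change.

A modest gain in this assay is expected, towards lower numbers, though a second limit remains quite possible. The estimated step is an at least 2.0-fold lower number from compound 1 to compound 3 (0.30 log units; that floor lies within the scatter) in that direction. Compound 3 is expected to remain a weaker inhibitor than compound 2 at 2120 nM in this test. For compound 3 the estimated value is 15000 nM, with an expected range from 4000 nM to 50000 nM for the measurement.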

Compound 3, half-maximal inhibitory concentration: > 30000 nM
Compound 3 ended at the assay's limit; the forecaster's own chance of this, stated with the estimate: 40%; middle value at least 2.0-fold (0.30 log units) away from the limit.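

In this assay compound 3 gives > 30000 nM as a limit and not a number. Compound 1 also stands at a limit, so no step can be read between compound 1 and compound 3: the limit of > 30000 nM in this assay, at which 2 of the 3 values shown sit. The compounds shown leave open whether quinolin-3-yl in place of 1H-indol-6-yl on an amine nitrogen changes the true value at all.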